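Compound 1 and its 4-fluorophenyl counterpart, compound 4

The source may hold more compounds than are shown below. What is called first, only, known or untested is meant among the compounds shown, and "the series" means these compounds.

Compound 1 `CCCCNC(=O)N1Cc2c(NC(=O)c3ccccc3)nn(C(=O)C3CC3)c2C1` 3470 nM
Compound 2 `CCCCNC(=O)N1Cc2c(NC(=O)c3ccccc3)nn(C(=O)c3ccccc3)c2C1` 7470 nM
Compound 3 `CCCCNC(=O)N1Cc2c(NC(=O)c3ccc(C)cc3)nn(C(=O)c3ccccc3)c2C1` 23200 nM

In a functional assay on HCT-116 cells (Homo sapiens) for cytotoxicity, read by sulforhodamine B assay, with a stated time of 48 h (a higher number here means a weaker inhibitor, a lower number a stronger inhibitor), compound 1 stands lowest of the three, with compound 2 nearest. Compound 4 `CCCCNC(=O)N1Cc2c(NC(=O)c3ccc(F)cc3)nn(C(=O)C3CC3)c2C1` keeps the core of compound 1 and its cyclopropyl carbonyl but turns the phenyl of the benzamido group into 4-fluorophenyl: fluoro in place of hydrogen on an aromatic carbon in short, fluoro in place of hydrogen on an aromatic carbon. The closest measured change, methyl in place of hydrogen on an aromatic carbon, gave a 3.1-fold higher number from compound 2 to compound 3 (0.49 log units; beyond the scatter) as a modest rise. The step of a 2.2-fold higher number from compound 1 to compound 2 (0.33 log units; beyond the scatter) lies at the other carbonyl and bears less. Going by the values given here, no measured compound carries fluoro, so only a small upward move is expected in this assay with a 1.3-fold higher number from compound 1 to compound 4 (0.11 log units; within the scatter) as the estimated step. For compound 4 the estimate is 4500 nM and the expected range runs from 1800 nM to 12000 nM.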

Compound 4, half-maximal inhibitory concentration: 23300 nM
Beside the measured number, compound 4's estimate is 5.2-fold (0.71 log units) below it; measured number outside the range, above it.
By their numbers in this assay, from the lowest: compound 1; then compound 2; then compounds 3 and 4 (each within the scatter of the next).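

In this assay a single fluoro on the phenyl of the benzamido group gives a 6.7-fold higher number from compound 1 to compound 4 (0.83 log units; beyond the scatter), so swapping hydrogen for one heavy atom at this position is not a neutral change. With a 3.1-fold higher number from compound 2 to compound 3 (0.49 log units; beyond the scatter) alongside it, both substituents placed here raise the number, one with a benzoyl group and one with a cyclopropyl carbonyl on the core. Nothing available explains this rise.

Going by these compounds, it remains open whether fluoro would raise the number equally with the benzoyl group of compound 2, and whether a methoxy group or an amine on this aromatic carbon would do the same.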